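Adding a Methoxy to the Benzoyl Group of Compound 3

The source may hold more compounds than are shown below. What is called first, only, known or untested is meant among the compounds shown, and "the series" means these compounds.

In a functional assay on HepG2 cells (Homo sapiens) for inhibition, read by MTT assay, with a stated time of 24 h (on this read-out lower numbers stand for stronger inhibition of growth and higher numbers for weaker inhibition of growth), compound 1 `Cn1cc(-c2nc3ccccc3n2C(=O)c2ccccc2)c2ccccc21` gives 42300 nM, and compound 2 `COc1ccc(C(=O)n2c(-c3cn(C)c4ccccc34)nc3ccccc32)cc1` gives 15200 nM. Compound 3 `COc1ccc2c(c1)c(-c1nc3ccccc3n1C(=O)c1ccccc1)cn2C` gives 37900 nM, so it sits towards the weak end of this small set and cannot be told apart from compound 1. Compound 4 `COc1cccc(C(=O)n2c(-c3cn(C)c4ccc(OC)cc34)nc3ccccc32)c1` is compound 3 with one further change, from benzoyl to (3-methoxyphenyl)carbonyl: methoxy in place of hydrogen on an aromatic carbon.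

Two measured steps also put methoxy in place of hydrogen on an aromatic carbon, but they do not agree. With the methoxy on the benzoyl group, there is a 2.8-fold lower number from compound 1 to compound 2 (0.44 log units; beyond the scatter), a modest strengthening. With the methoxy elsewhere in the molecule, there is a 1.1-fold lower number from compound 1 to compound 3 (0.05 log units; within the scatter), which amounts to no real change. Going by the values given here, the change in compound 4 also falls on the benzoyl group, so the first step is the closer guide, although its methoxy sits on a different carbon and this is only a single example. A somewhat smaller move towards a lower number therefore seems likely, and the expected step is a 1.7-fold lower number from compound 3 to compound 4 (0.24 log units; within the scatter). For compound 4 the estimated value is 22000 nM, with an expected range of 9000 nM to 48000 nM.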

Compound 4, concentration for 50% growth inhibition: 11700 nM
Compound 4: middle estimate off by 1.9-fold (0.27 log units), on the high side; the range from low to high includes it.
By their numbers in this assay, from the lowest: compounds 4 and 2 (each within the scatter of the next); then compounds 3 and 1 (each within the scatter of the next).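

Placing a methoxy on the benzoyl ring, meta to a large group, gives a 3.2-fold lower number from compound 3 to compound 4 (0.51 log units; beyond the scatter) in this assay, so a real gain is seen at this carbon. Until now the only gain from a methoxy on the benzoyl ring had been seen on the core of compound 1, and it now appears again when a second methoxy is already present elsewhere in the molecule, with the two steps closely matched: the same change on two cores in this assay, a 2.8-fold lower number (0.44 log units; beyond the scatter) from compound 1 to compound 2 and a 3.2-fold lower number (0.51 log units; beyond the scatter) from compound 3 to compound 4, 1.2-fold (0.07 log units) apart, within the scatter of two such steps

That second methoxy had made no real difference by itself, as a 1.1-fold lower number from compound 1 to compound 3 (0.05 log units; within the scatter) shows, yet its presence does not cancel the gain from the benzoyl methoxy in this pair of steps.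

The two benzoyl steps place the methoxy on different carbons and start from different cores, so the compounds shown cannot separate the effect of the carbon from that of the core. Going by these compounds, it also remains open whether the gain is specific to methoxy or would also appear with a hydroxyl, an amine, or a longer chain such as ethoxy on this same carbon.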